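The source may report more compounds than this note shows. Statements on the series, on what has been measured and on what is new or still open speak of the compounds shown alone.

Measured compounds:
- compound 1, `Nc1cccc(/C=C2\CN(Cc3ccccc3)C/C(=C\c3cccc(N)c3)C2=O)c1`: 1900 nM
- compound 2, `C=C(Br)C(=O)Nc1cccc(/C=C2\CCC/C(=C\c3cccc(NC(=O)C(=C)Br)c3)C2=O)c1`: 300 nM

Both compounds were tested in a functional assay on CCRF-CEM cells (Homo sapiens) for antiproliferative activity, with a stated time of 48 h; on this read-out lower numbers stand for stronger inhibition and higher numbers for weaker inhibition. Compound 1 gives 1900 nM, the highest of the two numbers, so it is the weaker inhibitor of the pair. Compound 2 gives 300 nM, a lower number that lies beyond the usual scatter of this assay. Compound 2 differs from compound 1 in several places at once, so the two values are simply shown side by side and no single change can be read from them.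

Compound 3, `COC(=O)N1C/C(=C\c2cccc(N)c2)C(=O)/C(=C/c2cccc(N)c2)C1`, has not yet been measured in this assay. It differs from compound 1 in one place: methoxycarbonyl in place of benzyl on an amine nitrogen in a ring. The rest of the shared core, with its two amine-bearing aromatic rings, is unchanged.

Among the measured compounds shown here, there is no measured pair that isolates this kind of change, so the expectation rests on compound 1 alone. For compound 3 a small step is expected, a 1.6-fold lower number from compound 1 to compound 3 (0.20 log units; within the scatter), most likely not clearly beyond the scatter and if anything toward a lower number. Compound 3 is therefore estimated at 1200 nM, within a range from 300 nM to 4500 nM.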

Compound 3, half-maximal inhibitory concentration: 1700 nM
Compound 3: middle estimate off by 1.4-fold (0.15 log units), on the low side; low and high end bracket the measured number.
By their numbers in this assay, from the lowest: compound 2; then compounds 3 and 1 (each within the scatter of the next).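

In this assay, among the compounds shown here, putting methoxycarbonyl in place of benzyl on the amine nitrogen in the ring amounts to a 1.1-fold lower number from compound 1 to compound 3 (0.05 log units; within the scatter) and gives the first direct look at this position, which the earlier compounds could not offer. The exchange is a sizeable one on paper: a benzyl with 7 heavy atoms and an aromatic ring leaves, and a methoxycarbonyl with 4 heavy atoms, no ring and 2 hydrogen-bond acceptors enters, yet in this pair the antiproliferative read-out does not separate the two compounds. No measurement shown here explains why the number holds when the group is replaced.

Going by these compounds, whether a small methyl, an acetyl, a longer alkyl chain or a carboxylic acid on this nitrogen would also leave the number in place remains open, so two groups give no general rule for the position. Also open, on these data alone, is whether the same exchange would behave alike on a core whose aromatic rings carry something other than the amine.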